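A few compounds are considered here, and "the series" means these few. Any claim that something is new, unique, unknown or untested is made for them only; others in the source may bear on it.

Compound 1, `Cc1cc(C)c(Oc2ccnc(Nc3ccc(C#N)cc3)n2)c(C)c1`, gives 1.82 in a physicochemical assay for lipophilicity; on this read-out higher numbers stand for higher lipophilicity and lower numbers for lower lipophilicity.
Compound 2, `Cc1cccc(C)c1Nc1ccnc(Nc2ccc(C#N)cc2)n1`, gives 1.49 in this assay.
Compound 3, `Cc1cc(Br)cc(C)c1Nc1ccnc(Nc2ccc(C#N)cc2)n1`, gives 1.54 in this assay.

Compound 3 differs from compound 2 by one change, (bromo in place of hydrogen on an aromatic carbon), and the result was a number 0.05 log units higher from compound 2 to compound 3 (within the scatter). How the core of compound 1 differs from the core of compound 2 is not broken down here. Compound 4, `Cc1cc(C)c(Oc2nc(Nc3ccc(C#N)cc3)ncc2Br)c(C)c1`, is not yet measured; it differs from compound 1 by bromo in place of hydrogen on an aromatic carbon. This is the same kind of change as from compound 2 to compound 3, not the same: there the bromo sits on a six-membered aromatic ring of carbon only, meta to two methyl groups and para to a large group, whereas in compound 4 it sits on a six-membered aromatic ring with 2 nitrogen, ortho to a large group, two atoms from the ring nitrogen and para to a group of 9 heavy atoms. Resting on a number 0.05 log units higher from compound 2 to compound 3 (within the scatter), the expected step is a number 0.13 log units higher from compound 1 to compound 4 (within the scatter). Compound 4 is therefore estimated at 1.95, likely between 1.6 and 2.3.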

Compound 4, partition coefficient: 1.82
For compound 4 the middle estimate is 0.13 log units above the measured one; the range from low to high includes it.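

In this assay, bromo in place of hydrogen on an aromatic carbon of the core of compound 1 gave no change at the digits printed from compound 1 to compound 4 (within the scatter), and the same kind of change on the core of compound 2 gave a number 0.05 log units higher from compound 2 to compound 3 (within the scatter), so in both pairs the change stayed small enough to be lost in the usual variation between repeats. For the compounds shown here, this does not show that bromo leaves the number unchanged on every core: there are only two pairs, and the cores and the places of the bromo differ, so their separate contributions cannot be told apart. Nothing given here explains either result. From the compounds shown here alone, whether an amine or a carboxylic acid in place of the bromo on the core of compound 1 would move the number beyond that variation remains open. So does whether bromo would give a similarly small step on other cores.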